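The compounds below may be only part of what the source reports. "The series", "measured", "known", "first", "only" and "open" are said of these compounds alone.

In a functional assay on HeLa cells (Homo sapiens) for antiproliferative activity, read by MTT assay, with a stated time of 72 h (a higher number here means a weaker inhibitor, a lower number a stronger inhibitor), compound 1 `COc1ccc(N2C(=O)COc3ccc(-c4ccc(O)cc4)cc32)cc1` gives 16400 nM, compound 3 `O=C1COc2ccc(-c3cnc(Cl)c(NS(=O)(=O)c4ccc(F)cc4)c3)cc2N1` gives 15600 nM, and compound 2 `COc1ncc(-c2ccc3c(c2)NC(=O)CO3)cc1NS(=O)(=O)c1ccc(F)cc1` gives 7110 nM, the lowest of the three numbers. Compound 4 `COc1ncc(-c2ccc3c(c2)N(C2CC2)C(=O)CO3)cc1NS(=O)(=O)c1ccc(F)cc1` differs from compound 2 by one change: cyclopropyl in place of hydrogen on an amide-type nitrogen in a ring. Going by the values given here, only one measured step is available, a 2.2-fold higher number from compound 2 to compound 3 (0.34 log units; beyond the scatter), with chloro in place of methoxy on an aromatic carbon. It is modest and concerns a different place, so the data offer no direct guide to this change or its direction. The expected change is small, with an estimated step of a 1.1-fold lower number from compound 2 to compound 4 (0.04 log units; within the scatter). Compound 4 is expected to give about 6500 nM, with an estimated range of 2000 nM to 20000 nM.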

Compound 4, half-maximal inhibitory concentration: 6030 nM
Compound 4: middle estimate off by 1.1-fold (0.03 log units), on the high side; the range from low to high includes it.
By their numbers in this assay, from the lowest: compounds 4 and 2 (each within the scatter of the next); then compounds 3 and 1 (each within the scatter of the next).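

In this assay the cyclopropyl in place of the amide hydrogen gives a 1.2-fold lower number from compound 2 to compound 4 (0.07 log units; within the scatter) and so leaves the number within the scatter, which shows that this amide-type nitrogen can carry a small carbon ring in this series without a measurable shift. The earlier step concerned a different place and said nothing about this nitrogen. Nothing available explains this outcome. The compounds shown leave open whether a longer chain, an amine or a carboxylic acid on this nitrogen would give a similar number.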